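Working notes on compound 4: fluorophenyl repositioned

The compounds below may be only part of what the source reports. "The series", "measured", "known", "first", "only" and "open" are said of these compounds alone.

Measured so far, in a functional assay on HEK293 cells with D(4) dopamine receptor (Homo sapiens) as the target, read by FLIPR; on this read-out higher numbers stand for an effect only at larger amounts of compound and lower numbers for an effect already at smaller amounts:
- compound 1 `O/N=C(/CCN1CCN(c2ccccn2)CC1)c1ccccc1`: 21.7 nM
- compound 2 `O/N=C(/CCN1CCN(c2ccccn2)CC1)c1ccccc1Cl`: 25 nM
- compound 3 `O/N=C(\CCN1CCN(c2ccccn2)CC1)c1cccc(F)c1`: 17.1 nM

Compound 3 has the lowest of the three numbers, but its nearest neighbour is compound 1 and its furthest is compound 2, and both gaps lie within the scatter, so on this assay the three measured compounds are indistinguishable.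

Compound 4 `O/N=C(\CCN1CCN(c2ccccn2)CC1)c1ccc(F)cc1` is not yet measured. It differs from compound 3 as follows: 4-fluorophenyl in place of 3-fluorophenyl on a carbon with a double bond to nitrogen. The two share every atom and differ only in where the fluorine sits on the six-membered aromatic ring of carbon only.

Among the measured compounds shown here, the one step measured within one place, a 1.2-fold higher number from compound 1 to compound 2 (0.06 log units; within the scatter), concerns a chloro entering for hydrogen and stays within the scatter. For the measured compounds named here, no measured step moves a fluorine from one ring position to another, so nothing speaks directly to the change from compound 3 to compound 4. Going by the values given here, the only available guide is that all substitution changes seen so far have left this assay essentially unchanged.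

Compound 4 is therefore expected to sit close to compound 3, with a 1.5-fold higher number from compound 3 to compound 4 (0.16 log units; within the scatter) as the expected step, i.e. nothing beyond the scatter. The estimate for compound 4 is 25 nM, with a range from 10 nM to 65 nM.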

Compound 4, half-maximal effective concentration: 31 nM
Beside the measured number, compound 4's estimate is 1.2-fold (0.09 log units) below it; the range from low to high includes it.
By their numbers in this assay, from the lowest: compounds 3, 1, 2 and 4 (each within the scatter of the next).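

In this assay, this is the first step that moves a fluorine around the aromatic ring while the rest of the structure stays fixed, and 4-fluorophenyl in place of 3-fluorophenyl gives a 1.8-fold higher number from compound 3 to compound 4 (0.26 log units; within the scatter), so the fluorine's ring position on the carbon with a double bond to nitrogen is not shown to matter on this read-out. Together with a 1.2-fold higher number from compound 1 to compound 2 (0.06 log units; within the scatter), this gives two steps at the aromatic ring, one a chloro in place of hydrogen and one a repositioned fluorine, and neither lies beyond the scatter, although the claim reaches only these four compounds. Nothing at hand offers an explanation for the size of the fluorine step.

On these data alone, it remains open whether a larger or differently charged group on the aromatic ring, such as a nitrile, a carboxylic acid or an amine in place of the fluorine, would produce a step beyond the scatter. As far as these compounds go, a longer chain in the shared core is equally open, as is the behaviour of these fluorophenyl compounds at other dopamine receptors.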